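Saturated Ring Replaces Oxazole: Stability Outlook for Compound 4

The source may hold more compounds than are shown below. What is called first, only, known or untested is meant among the compounds shown, and "the series" means these compounds.

Compound 1 (`Cn1cc(-c2nc3c(-c4ccnc(OC5CC5)c4)cnn3cc2OCC(C)(C)O)cn1`) in an ADME assay on microsomes from liver (Rattus norvegicus) for metabolic stability, with a stated time of 60 min, tested at 1 uM; on this read-out higher numbers stand for a more stable compound and lower numbers for a less stable compound: 81%
Compound 2 (`COc1cc(-c2cnn3cc(OC)c(-c4cc(C)no4)nc23)ccn1`) in this assay: 62%
Compound 3 (`COc1cc(-c2cnn3cc(OC)c(C(C)C)nc23)ccn1`) in this assay: 14%

Compound 2 stands second highest of the three numbers in this assay; compound 1 lies above it beyond the scatter, compound 3 far below it. Compound 4 (`COc1cc(-c2cnn3cc(OC)c([C@H]4COC(C)(C)C4)nc23)ccn1`) differs from compound 2 in one place: a group of 7 heavy atoms (6 carbon, 1 oxygen; one five-membered non-aromatic ring with 1 hetero atom) in place of a group of 6 heavy atoms (4 carbon, 1 nitrogen, 1 oxygen; one five-membered aromatic ring with 2 hetero atoms), on an aromatic carbon. Among the measured compounds shown here, one measured step bears on this change, a number 48 percentage points lower from compound 2 to compound 3 (beyond the scatter), where an isopropyl took the place of the same 3-methyl-1,2-oxazol-5-yl on the same aromatic carbon. The group entering compound 4 is likewise non-aromatic, so a step in the same direction is expected, estimated as a number 32 percentage points lower from compound 2 to compound 4 (beyond the scatter). Compound 4 is therefore expected to give about 30% in this assay, with a range from 10% to 55%.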

Compound 4, percent of the compound remaining: 30%
Beside the measured number, compound 4's estimate shows no gap at the digits printed, and the stated range covers the measured number.
By their numbers in this assay, from the lowest: compound 3; then compound 4; then compound 2; then compound 1.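

In this assay the step of a number 32 percentage points lower from compound 2 to compound 4 (beyond the scatter) shows that a second non-aromatic group on this aromatic carbon also falls well short of the 3-methyl-1,2-oxazol-5-yl. The step of a number 16 percentage points higher from compound 3 to compound 4 (beyond the scatter) shows that non-aromatic groups here are not interchangeable, so the number depends on which group enters and not only on the aromatic ring leaving. No measurement at hand explains either step.

The compounds shown leave open whether a different aromatic ring, such as phenyl or pyridine, would match the 3-methyl-1,2-oxazol-5-yl here. They also leave open how the mirror-image form of the entering ring would compare.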